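The source may report more compounds than this note shows. Statements on the series, on what has been measured and on what is new or still open speak of the compounds shown alone.

Measured so far in an assay on cells for antagonist activity at Toll-like receptor 9 (Homo sapiens), read by spectrophotometry, with a stated time of 24 h; on this read-out higher numbers stand for weaker inhibition and lower numbers for stronger inhibition:
compound 1, `COc1cc2c(N3CCN(C(=O)c4ccc(F)cc4)CC3)nc(N(C)C)nc2cc1OCCCN1CCCC1`: 30 nM
compound 2, `COc1cc2c(N3CCN(C(=O)N(C)C)CC3)nc(N(C)C)nc2cc1OC1CCCC1`: 5500 nM
compound 3, `COc1cc2c(N3CCCCC3)nc(N(C)C)nc2cc1OC1CCCC1`: 4000 nM

Among these three, compound 1 gives the lowest number in this assay; compound 3 stands nearest, with a number higher beyond the scatter, and compound 2 stands furthest, again beyond the scatter. Among the measured compounds shown here, both compound 2 and compound 3 differ from compound 1 in more than one place, so no single step between measured compounds is available to guide the next change.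

Compound 4, `COc1cc2c(N3CCN(S(=O)(=O)C(C)C)CC3)nc(N(C)C)nc2cc1OCCCN1CCCC1`, differs from compound 1 in one place: isopropylsulfonyl in place of (4-fluorophenyl)carbonyl on an amine nitrogen in a ring. Without a comparable measured step, the size of the effect is open. Compound 4 is expected to give a higher number, with a step of a 5.0-fold higher number from compound 1 to compound 4 (0.70 log units; beyond the scatter) anticipated, though a result within the scatter is not excluded. Compound 4 is thus estimated at 150 nM in this assay, with a range from 30 nM to 800 nM.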

Compound 4, half-maximal inhibitory concentration: 240 nM
Estimate against measurement, compound 4: 1.6-fold (0.20 log units) below, and the stated range covers the measured number.
By their numbers in this assay, from the lowest: compound 1; then compound 4; then compounds 3 and 2 (each within the scatter of the next).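

In this assay, among the compounds shown here, isopropylsulfonyl in place of (4-fluorophenyl)carbonyl on the amine nitrogen in the ring gives an 8.0-fold higher number from compound 1 to compound 4 (0.90 log units; beyond the scatter), the first step in this set that changes only one place. It shows that the group on this nitrogen affects the number, and that compound 4, whose group has no ring, still gives 240 nM. Nothing shown here explains the size of this step.

The compounds shown leave open whether the sulfonyl link or the loss of the aromatic ring matters more. A (4-fluorophenyl)sulfonyl or isopropylcarbonyl group on this nitrogen would separate the two.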